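Permeability of a phenethyl analogue of compound 2

The compounds below may be only part of what the source reports. "The series", "measured", "known", "first", "only" and "open" are said of these compounds alone.

Measured compounds:
compound 1, `COc1cccc(CNCCCNc2ccnc3cc(C4CCCCC4)ccc23)c1O`, 23 10^-6 cm/s
compound 2, `COc1ccc(F)cc1CNCCCNc1ccnc2cc(C3CCCCC3)ccc12`, 23 10^-6 cm/s
compound 3, `c1ccc(-c2ccc3c(NCCCNCc4ccco4)ccnc3c2)cc1`, 237 10^-6 cm/s

In an ADME assay for permeability, using PAMPA, with a stated time of 30 min, at pH 7.4 (a lower number here means that the compound crosses the layer more slowly, a higher number that the compound crosses the layer faster), compound 2 gives 23 10^-6 cm/s. It stands level with compound 1 within the scatter, and the two together give the lowest numbers of the three; compound 3 gives 237 10^-6 cm/s, a number far higher than that of compound 2 and beyond the scatter. Within the data shown here, the only single-point step among the measured compounds, no change at the digits printed from compound 1 to compound 2 (within the scatter), exchanges one aryl group on the chain carbon bound to the amine nitrogen and leaves this assay unchanged within the scatter.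

Compound 4, `COc1ccc(F)cc1CNCCCNc1ccnc2cc(CCc3ccccc3)ccc12`, differs from compound 2 at a different position: phenethyl in place of cyclohexyl on an aromatic carbon. Among the measured compounds shown here, no measured step touches this position alone, since compound 3 differs from compound 2 in two places. For the measured compounds named here, the account therefore rests on the observation that the one exchange seen so far, from compound 1 to compound 2, left this assay flat. The step from compound 2 to compound 4 is estimated as a 1.3-fold higher number from compound 2 to compound 4 (0.12 log units; within the scatter), within the scatter. Compound 4 is expected to give about 30 10^-6 cm/s in this assay, in the range 12 10^-6 cm/s to 75 10^-6 cm/s.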

Compound 4, apparent permeability: 23 10^-6 cm/s
Estimate against measurement, compound 4: 1.3-fold (0.12 log units) above; measured number inside the range.
By their numbers in this assay, from the lowest: compounds 1, 2 and 4 (each within the scatter of the next); then compound 3.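

Phenethyl in place of cyclohexyl on an aromatic carbon gives no change at the digits printed from compound 2 to compound 4 (within the scatter) in this assay and is the first single-place step at this position. Among these compounds, until now, the only such step among the compounds had been the aryl exchange on the chain carbon bound to the amine nitrogen, so the flat reading at this aromatic carbon is new. The exchange is also not a small one on paper, since an aromatic ring enters in place of a non-aromatic one and the group goes from 6 to 8 heavy atoms, all carbon, with no hydrogen-bond donors or acceptors on either side, and yet the two compounds cannot be told apart here.

Still open, from the compounds shown here alone, is whether a group carrying other atoms at this carbon, such as an amine or a carboxylic acid, or a longer chain than phenethyl, would stay as flat as this exchange did. Compound 3, at 237 10^-6 cm/s in this assay, differs from compound 2 in two places, so its number cannot be read as a step at this position alone, and nothing given here explains the flat result.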